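Working notes: 3-(dimethylamino)azetidin-1-yl in place of 4-methylpiperazin-1-yl

A few compounds are considered here, and "the series" means these few. Any claim that something is new, unique, unknown or untested is made for them only; others in the source may bear on it.

In a toxicity assay on Huh-7.5 cells (Homo sapiens) for inhibition, read by MTT assay, with a stated time of 96 h (a lower number here means that less compound is tolerated, a higher number that more compound is tolerated), compound 3 `CN1CCN(Cc2ccc(NC(=O)c3ccc(OCCCCl)c([N+](=O)[O-])c3)cc2C(F)(F)F)CC1` gives 6800 nM, within the scatter of compound 1 `CN(C)C1CCN(Cc2ccc(NC(=O)c3ccc(OCCCCl)c([N+](=O)[O-])c3)cc2C(F)(F)F)C1` at 5800 nM, while compound 2 `CC1CN(Cc2ccc(NC(=O)c3ccc(OCCCCl)c([N+](=O)[O-])c3)cc2C(F)(F)F)CC(C)O1` gives 2300 nM. Compound 4 `CN(C)C1CN(Cc2ccc(NC(=O)c3ccc(OCCCCl)c([N+](=O)[O-])c3)cc2C(F)(F)F)C1` carries 3-(dimethylamino)azetidin-1-yl in place of 4-methylpiperazin-1-yl on a saturated chain carbon bound to an aromatic carbon. Both steps beyond the scatter, a 2.5-fold lower number from compound 1 to compound 2 (0.40 log units; beyond the scatter) and a 3.0-fold higher number from compound 2 to compound 3 (0.47 log units; beyond the scatter), involve 2,6-dimethylmorpholin-4-yl, a group absent from compound 4. On the strength of a 1.2-fold higher number from compound 1 to compound 3 (0.07 log units; within the scatter), which exchanges 3-(dimethylamino)pyrrolidin-1-yl and 4-methylpiperazin-1-yl, no step beyond the scatter is expected in this assay. The expected step is a 1.1-fold lower number from compound 3 to compound 4 (0.05 log units; within the scatter). For compound 4 the estimated value is 6000 nM, with an expected range of 3000 nM to 12000 nM.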

Compound 4, half-maximal cytotoxic concentration: 7800 nM
Compound 4: the middle estimate sits 1.3-fold (0.11 log units) below what was measured; the measured number falls inside the stated range.
By their numbers in this assay, from the lowest: compound 2; then compounds 1, 3 and 4 (each within the scatter of the next).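

In (this assay), exchanging 4-methylpiperazin-1-yl for 3-(dimethylamino)azetidin-1-yl on a saturated chain carbon bound to an aromatic carbon, with the same atoms joined differently and a four-membered in place of a six-membered ring, leaves the number within the scatter (a 1.1-fold higher number from compound 3 to compound 4 (0.06 log units; within the scatter)), and the same holds against compound 1 (a 1.3-fold higher number from compound 1 to compound 4 (0.13 log units; within the scatter)). Going by these compounds alone, compound 2 remains the only compound set apart, now also by a step beyond the scatter (a 3.4-fold higher number from compound 2 to compound 4 (0.53 log units; beyond the scatter)). No measurement shown explains these numbers.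

Open, on these data alone, is whether a primary amine or a carboxylic acid at this place would stay within the scatter of compound 4. The compounds shown vary this one place only, so changes elsewhere on the shared core remain unread.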